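Chloro on the phenyl ring: expected effect on PC-3 proliferation

The compounds below may be only part of what the source reports. "The series", "measured", "known", "first", "only" and "open" are said of these compounds alone.

Measured so far:
compound 1, `COc1cc(OC)c(C(=O)/C=C/c2ccccc2SC)c(OC)c1` — 0%
compound 2, `COc1cc(OC)c(C(=O)/C=C/c2ccccc2)c(OC)c1` — 1.7%

Compound 1 carries a methylsulfanyl on the phenyl ring; in a functional assay on PC-3 cells (Homo sapiens), read by fluorescence and BrdU incorporation, with a stated time of 48 h, tested at 25 uM (a higher number here means a weaker effect of the compound at the concentration tested, a lower number a stronger effect), compound 1 gives 0%. Compound 2, `COc1cc(OC)c(C(=O)/C=C/c2ccccc2)c(OC)c1`, is the same core with hydrogen in place of methylsulfanyl on an aromatic carbon, and in this assay compound 2 gives 1.7%. Among the compounds with values here, compound 2 stands as the higher of the two numbers, but the only measured step, a number 1.7 percentage points higher from compound 1 to compound 2 (within the scatter), is within the scatter, so the two compounds cannot be told apart: both show essentially no effect.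

Compound 3, `COc1cc(OC)c(C(=O)/C=C/c2ccc(Cl)cc2)c(OC)c1`, differs from compound 2 by chloro in place of hydrogen on an aromatic carbon, the phenyl becoming 4-chlorophenyl. Within the data shown here, no measured step involves a chloro group, so the single step from compound 1 to compound 2 bears on it only indirectly, and that step was within the scatter. Since neither compound 1 nor compound 2 produced a response, a chloro at this position is not expected to change the picture.

For compound 3 in this assay the estimate is 3%, between 0% and 14%, which means an expected step of a number 1.3 percentage points higher from compound 2 to compound 3 (within the scatter), not beyond the scatter.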

Compound 3, a percentage reported as activity, at one concentration (the size of the read-out at that concentration, not a potency): 0.2%
Estimate against measurement, compound 3: 2.8 percentage points above; the range from low to high includes it.
By their numbers in this assay, from the lowest: compounds 1, 3 and 2 (each within the scatter of the next).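

Putting chloro on the aromatic carbon para to a large group gives the first view of a substituent at this place, and in this assay it moves the read-out by only a number 1.5 percentage points lower from compound 2 to compound 3 (within the scatter), so this hydrogen can be replaced by chloro without any visible loss of effect. Compound 3 also cannot be told apart from the methylsulfanyl compound, with a number 0.2 percentage points higher from compound 1 to compound 3 (within the scatter), which means that 4-chlorophenyl and 2-(methylsulfanyl)phenyl both fit the shared core equally well as far as this read-out can show, and all three compounds sit at the low end of a scale on which a lower number means a stronger effect. Nothing available explains why the read-out stays the same across these changes.

At a single concentration with numbers this low, any real difference among the three compounds could stay hidden, so a lower concentration might yet separate them. Going by these compounds, it also remains open whether a more different group in the same place, such as an amine or a carboxylic acid, would keep the effect or lose it.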